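Replacing the Chlorophenyl Group: Expected Inhibition of Compound 3

This account rests on a few compounds, and the source may have more. Where it says the series, first, only, none or still open, it means among the compounds named here.

Compound 1 `Cc1ccc(C(=O)CCc2nnc(-c3ccc(Cl)cc3)o2)cc1`: 81.5%
Compound 2 `Cc1ccc(C(=O)CCc2nnc(-c3ccc(Cl)cc3)o2)c(C)c1`: 72.6%

Both were tested in a functional assay on the whole organism (strain Wistar) for inhibition, with Rattus norvegicus as the target, with stated times of 30 min and 3 h, at a dose of 20 mg/kg by the oral route; on this read-out higher numbers stand for more inhibition at the one dose given (going by the name of the read-out) and lower numbers for less inhibition. Compound 2 gives the lower of the two numbers, but the step of a number 8.9 percentage points lower from compound 1 to compound 2 (within the scatter) lies within the scatter, so the two are not told apart. Compound 3 `Cc1ccc(C(=O)CCc2nnc(COc3ccccc3)o2)c(C)c1` differs from compound 2 by phenoxymethyl in place of 4-chlorophenyl on an aromatic carbon. Among the measured compounds shown here, the single measured step concerns a methyl group, not the group now exchanged, so no measured step bears on this change. A wide range is therefore expected, with a lower number thought somewhat more likely than a higher one. For compound 3 the estimate in this assay is 55%, between 25% and 85%, meaning an expected step of a number 17.6 percentage points lower from compound 2 to compound 3 (beyond the scatter).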

Compound 3, a percentage reported as inhibition, in the whole organism at one dose (the size of the read-out at that dose, not a potency): 45.7%
Estimate against measurement, compound 3: 9.3 percentage points above, within the range that was stated.
By their numbers in this assay, from the lowest: compound 3; then compounds 2 and 1 (each within the scatter of the next).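

The exchange of 4-chlorophenyl for phenoxymethyl gives a number 26.9 percentage points lower from compound 2 to compound 3 (beyond the scatter) in this assay. Among the compounds shown here, this is the first step that lies beyond the scatter, so the group at this place on the five-membered aromatic ring clearly affects the read-out. Nothing measured here explains the drop.

As far as these compounds go, the exchange removes the chlorine and adds an oxygen in a single step, so the contribution of each remains open. Plain phenyl or 4-chlorophenoxymethyl at this place would help separate them.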